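The compounds below may be only part of what the source reports. "The series", "measured", "known", "first", "only" and "open" are said of these compounds alone.

Compound 1 `CCN1C(=O)CS/C1=N/Nc1nncc2ccccc12`: 28 nM
Compound 2 `Cc1cc(C)nc(NS(=O)(=O)c2ccc(Nc3nncc4ccccc34)cc2)n1`: 0.8 nM
Compound 3 `S=C(NNc1nncc2ccccc12)Nc1ccccc1`: 16 nM

All three values come from a functional assay on NCI-H460 cells (Homo sapiens) for antiproliferative activity, read by sulforhodamine B assay, with a stated time of 72 h; on this read-out lower numbers stand for stronger inhibition and higher numbers for weaker inhibition. Compound 2 gives the lowest number of the three. Compound 3 at 16 nM and compound 1 at 28 nM both lie above it, beyond the scatter.

Compound 4 `O=S(=O)(Nc1ccccn1)c1ccc(Nc2nncc3ccccc23)cc1` has not yet been measured. It carries pyridin-2-yl in place of 4,6-dimethylpyrimidin-2-yl on a sulfonamide nitrogen. Among the measured compounds shown here, no measured pair shows what this exchange does, so the expectation rests only on compound 2 at 0.8 nM and on the change itself. Compound 4 keeps the sulfonamide of compound 2, which neither compound 1 nor compound 3 has, so a low number is still expected in this assay, though a modest move towards weaker inhibition seems more likely than a gain. The expected step, a 3.1-fold higher number from compound 2 to compound 4 (0.49 log units; beyond the scatter), is an estimate only. For compound 4 the estimated value is 2.5 nM, with an expected range of 0.5 nM to 15 nM.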

Compound 4, half-maximal inhibitory concentration: 43 nM
Estimate against measurement, compound 4: 17-fold (1.24 log units) below, outside the stated range (above it).
By their numbers in this assay, from the lowest: compound 2; then compounds 3, 1 and 4 (each within the scatter of the next, the first and the last beyond it).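

On the sulfonamide nitrogen, this position proves highly sensitive in this assay: pyridin-2-yl in place of 4,6-dimethylpyrimidin-2-yl gives a 54-fold higher number from compound 2 to compound 4 (1.73 log units; beyond the scatter), so the low number of compound 2 depends on the group carried there and not on the sulfonamide alone. The exchange is small in what is counted, with the entering group still a six-membered aromatic ring, yet that is enough to lose most of the inhibition seen with compound 2. Nothing measured here explains why the step is so large.

The exchange alters the ring hetero atoms and removes the methyl groups at once, so the compounds shown leave open which of these changes carries the step. A plain pyrimidin-2-yl or a 4,6-dimethylpyridin-2-yl on the same sulfonamide nitrogen would separate the two.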